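Swapping the Five-Membered Ring on the Chloro-Bearing Phenyl

A few compounds are considered here, and "the series" means these few. Any claim that something is new, unique, unknown or untested is made for them only; others in the source may bear on it.

Of the compounds shown here, three sharing one core have been measured in an assay on isolated protein for inhibition of ubiquitin carboxyl-terminal hydrolase 7 (Homo sapiens), with stated times of 30 min and 2 h; a higher number here means a weaker inhibitor, a lower number a stronger inhibitor. Compound 1 `Cn1nc2c(=O)n(CC3(O)CCN(Cc4ccc(-c5n[nH]c(=O)o5)cc4Cl)CC3)cnc2c1-c1ccc(CN)cc1` gives 171 nM. Compound 2 `CC(C)NCc1ccc(-c2c3ncn(CC4(O)CCN(Cc5ccc(-c6ccco6)cc5Cl)CC4)c(=O)c3nn2C)cc1` gives 29.1 nM, and compound 3 `CCNCc1ccc(-c2c3ncn(CC4(O)CCN(Cc5ccc(-c6ccco6)cc5Cl)CC4)c(=O)c3nn2C)cc1` gives 15.2 nM. Compound 1 thus stands with the highest number of the three; its nearest neighbour, compound 2, sits beyond the scatter, and compound 3 further still. Going by the values given here, the one single-point step recorded, a 1.9-fold lower number from compound 2 to compound 3 (0.28 log units; within the scatter), concerns the amine end and not the ring that changes here.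

Compound 4 `Cn1nc2c(=O)n(CC3(O)CCN(Cc4ccc(-c5ccoc5)cc4Cl)CC3)cnc2c1-c1ccc(CN)cc1` differs from compound 1 by a group of 5 heavy atoms (4 carbon, 1 oxygen; one five-membered aromatic ring with 1 hetero atom) in place of a group of 6 heavy atoms (2 carbon, 2 nitrogen, 2 oxygen; one five-membered aromatic ring with 3 hetero atoms), on an aromatic carbon. Compounds 2 and 3 carry a related oxygen-bearing five-membered aromatic ring at that place, yet they also differ from compound 1 at the amine, so their gaps to compound 1 cannot be cleanly assigned to the ring. Among the compounds with values here, no measured step bears directly on this change. Compound 4 is therefore expected to move toward the lower numbers of compounds 2 and 3, as a 2.1-fold lower number from compound 1 to compound 4 (0.33 log units; beyond the scatter), with wide uncertainty. Compound 4 is estimated at 80 nM, within 30 nM to 250 nM.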

Compound 4, half-maximal inhibitory concentration: 177 nM
The estimate for compound 4 lay 2.2-fold (0.34 log units) below the measured number; the range from low to high includes it.
By their numbers in this assay, from the lowest: compounds 3 and 2 (each within the scatter of the next); then compounds 1 and 4 (each within the scatter of the next).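

In this assay, furan-3-yl in place of the ring with three hetero atoms, on the aromatic carbon para to a large group, gives a 1.0-fold higher number from compound 1 to compound 4 (0.01 log units; within the scatter), so the two rings cannot be told apart here. Going by these compounds alone, this is the first direct reading of this position, and it shows that with the core and amine end of compound 1 held fixed, the number does not respond to this exchange, even though the hydrogen-bond donor of the leaving ring is absent from furan-3-yl. Nothing measured here gives a reason for this result.

Still open, as far as these compounds go, is whether the furan-2-yl ring of compound 3 would read differently from furan-3-yl if paired with the amine end of compound 4. Also open, from the compounds shown here alone, is how a carboxylic acid or a primary amide at this position would read.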